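Removing the carboxy group from compound 2

This account rests on a few compounds, and the source may have more. Where it says the series, first, only, none or still open, it means among the compounds named here.

Measured in an ADME assay on Caco-2 cells (Homo sapiens) for cytotoxicity, with a stated time of 72 h; on this read-out higher numbers stand for weaker inhibition and lower numbers for stronger inhibition:
compound 1 `O=C(Nc1ccn(C[C@@H]2O[C@H](CO)[C@@H](O)[C@H](F)C2=O)c(=O)n1)c1ccccc1` gives 1500 ug/mL
compound 2 `O=C(O)OC[C@@H]1C=C(F)C(=O)[C@H](Cn2ccc(NC(=O)c3ccccc3)nc2=O)O1` gives 200 ug/mL

Going by the values given here, only two numbers are available so far. Compound 2 stands lowest at 200 ug/mL in this assay and thus shows the stronger inhibition. Its gap to compound 1 at 1500 ug/mL lies beyond the usual scatter. These two compounds differ in more than one place, so their gap cannot be pinned on any single change.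

The next structure is compound 3 (`O=C(Nc1ccn(C[C@@H]2O[C@H](CO)C=C(F)C2=O)c(=O)n1)c1ccccc1`). It has hydrogen in place of carboxy on an oxygen on a saturated carbon, so carboxyoxy becomes hydroxy and the rest of compound 2 stays the same. Among the compounds with values here, no measured pair shows this change on its own, which leaves the expectation resting on just two values. Compound 1 at 1500 ug/mL also carries hydroxymethyl, but it differs from compound 3 elsewhere, so it argues for only a slight upward shift. The expected move, a 1.3-fold higher number from compound 2 to compound 3 (0.10 log units; within the scatter), is small, slightly upward and not beyond the scatter. In this assay the estimated value for compound 3 is 250 ug/mL and the expected range runs from 80 ug/mL to 800 ug/mL on this estimate.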

Compound 3, half-maximal inhibitory concentration: 200 ug/mL
For compound 3 the middle estimate is 1.3-fold (0.10 log units) above the measured one, within the range that was stated.
By their numbers in this assay, from the lowest: compounds 2 and 3 (each within the scatter of the next); then compound 1.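

Going by these compounds alone, compound 2 and compound 3 are the first pair here that differ in one place only, so a single change can now be read on its own in this assay: putting hydrogen in place of carboxy on an oxygen on a saturated carbon gives no change at the digits printed from compound 2 to compound 3 (within the scatter) and turns carboxyoxy into hydroxy. At this position, then, a group of 3 heavy atoms gives way to a lone hydrogen, and the two compounds still stand within the scatter of each other, so this read-out does not tell (carboxyoxy)methyl from hydroxymethyl. Nothing measured on these compounds offers an explanation for this result, which stands as a plain observation.

Only one replacement on this oxygen is shown, so it remains open whether another group there, such as an acetyl ester or a methyl ether, would also stay within the scatter of compound 3. The gap between compound 1 and compound 2 also remains unassigned, since those two compounds differ in more than one place and no single change can yet be held to account for it.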